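This account rests on a few compounds, and the source may have more. Where it says the series, first, only, none or still open, it means among the compounds named here.

Of the compounds shown here, three sharing a core have been tested in an ADME assay on L132 cells (Homo sapiens) for inhibition, read by MTT assay, with a stated time of 72 h; a lower number here means a stronger inhibitor of growth, a higher number a weaker inhibitor of growth. In this assay compound 3 (`Nc1n[nH]c2cccc(C#Cc3cccc(C(=O)Nc4cccc(C(F)(F)F)c4)c3)c12`) gives 15300 nM, and compound 1 (`Cc1cn(-c2cc(C(=O)Nc3cccc(C#Cc4cccc5[nH]nc(N)c45)c3)cc(C(F)(F)F)c2)cn1`) gives 10900 nM. These two values lie within the scatter of each other. Compound 2 (`CN1CCN(c2ccc(C(=O)Nc3cccc(C#Cc4cccc5[nH]nc(N)c45)c3)cc2C(F)(F)F)CC1`) returned only a limit, > 10000 nM. Among the measured compounds shown here, compound 3 thus stands level with compound 1, the only other compound with a number.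

Compound 4 (`Cc1cn(-c2cc(NC(=O)c3cccc(C#Cc4cccc5[nH]nc(N)c45)c3)cc(C(F)(F)F)c2)cn1`) differs from compound 3 by a single change: 4-methyl-1H-imidazol-1-yl in place of hydrogen on an aromatic carbon. The 4-methyl-1H-imidazol-1-yl group replaces hydrogen on an aromatic carbon of a six-membered aromatic ring of carbon only, meta to a trifluoromethyl group. For the measured compounds named here, no two measured compounds differ in one place only, leaving this change without a direct measured precedent. Compound 1 also carries a 4-methyl-1H-imidazol-1-yl group, and with 10900 nM compound 1 remains within the scatter of compound 3. On that basis, no shift beyond the scatter is expected in this assay. The estimated change, a 1.2-fold lower number from compound 3 to compound 4 (0.07 log units; within the scatter), is small and within the scatter. For compound 4 the estimated value is 13000 nM, with an expected range from 6500 nM to 26000 nM.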

Compound 4, concentration for 50% growth inhibition: 12900 nM
Estimate against measurement, compound 4: 1.0-fold (0.00 log units) above; the measured number falls inside the stated range.
By their numbers in this assay, from the lowest: compounds 1, 4 and 3 (each within the scatter of the next).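

In this assay, among the compounds shown here, placing 4-methyl-1H-imidazol-1-yl in place of hydrogen on an aromatic carbon gives a 1.2-fold lower number from compound 3 to compound 4 (0.07 log units; within the scatter), and this is the first step between two measured compounds that differ in one place. The earlier compounds shown here offered no such pair, so they could not isolate this change; here it can be read directly, and it produces no shift beyond the scatter at this position, meta to a trifluoromethyl group. A group of 6 heavy atoms with a five-membered aromatic ring can therefore enter at this carbon, in the setting of compound 3, without moving the number measurably in this assay.

Going by these compounds, whether a different group at the same carbon, such as an amine, a carboxylic acid or a longer chain, would leave the number equally level remains open, as does whether 4-methyl-1H-imidazol-1-yl would behave the same way on another carbon of this ring. Compound 2 cannot be placed in the series, since its value is a limit and not a number: the limit of > 10000 nM in this assay, at which 1 of the 4 values shown sits.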